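The source may hold more compounds than are shown below. What is called first, only, known or untested is meant among the compounds shown, and "the series" means these compounds.

The series rests on a shared core, seen in compound 1 `CCCc1nnc(SCC(=O)c2ccc(Cl)cc2)n1N1C(=O)c2ccccc2C1=O` and in compound 2 `CCCc1nnc(SCC(=O)c2ccc(C)cc2)n1N1C(=O)c2ccccc2C1=O`, which differ in one place: methyl in place of chloro on an aromatic carbon. Compound 3 `COc1cc(-c2nnc(SCC(=O)c3ccc(Cl)cc3)n2N2C(=O)c3ccccc3C2=O)cc(OC)c1OC` carries a different core, and that difference from compound 1 is counted as 3,4,5-trimethoxyphenyl in place of propyl on an aromatic carbon. Compound 4 `COc1cc(-c2nnc(SCC(=O)c3ccc(C)cc3)n2N2C(=O)c3ccccc3C2=O)cc(OC)c1OC` is not yet measured and stands to compound 3 as compound 2 stands to compound 1, through (methyl in place of chloro on an aromatic carbon); the surroundings of the place are described in the same words for both pairs, so this is the same change.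

In a functional assay on PC-3M cells (Homo sapiens) for cytotoxicity, read by MTT assay, with a stated time of 48 h (a higher number here means a weaker inhibitor, a lower number a stronger inhibitor), compound 1 gives only a limit, > 200000 nM. In this assay compound 2 likewise gives only a limit, > 200000 nM. Hence a step that the two limits leave unreadable from compound 1 to compound 2, because both values sit at the limit of > 200000 nM in this assay, at which 2 of the 3 values shown sit. In this assay compound 3 gives 20700 nM, which is an at least 9.6-fold lower number from compound 1 to compound 3 (0.98 log units; beyond the scatter).

Within the data shown here, with the earlier instance of the change unreadable, there is no measured step to set the size of the step from compound 3 to compound 4; the only guide is that compound 3 gives a number, 20700 nM, rather than a limit. Compound 4 is therefore expected to stay near compound 3, with a 1.2-fold higher number from compound 3 to compound 4 (0.08 log units; within the scatter) as the estimated step. For compound 4 the estimated value in this assay is 25000 nM, expected to fall between 8000 nM and 80000 nM.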

Compound 4, half-maximal inhibitory concentration: 11700 nM
Beside the measured number, compound 4's estimate is 2.1-fold (0.33 log units) above it; measured number inside the range.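

In this assay, methyl in place of chloro gives a 1.8-fold lower number from compound 3 to compound 4 (0.25 log units; within the scatter), so on the core of compound 3 this change brings no step beyond the scatter. Compound 1 and compound 2 each give only a limit, so the same change cannot be read on their core, and nothing shows whether it would behave alike on both cores: the limit of > 200000 nM in this assay, at which 2 of the 4 values shown sit. The other change, 3,4,5-trimethoxyphenyl in place of propyl, gives an at least 17-fold lower number from compound 2 to compound 4 (1.23 log units; beyond the scatter), which shows that it carries over in the same direction whether chloro or methyl stands on the far ring, but the two sizes cannot be set against each other: the same change on two cores in this assay, an at least 9.6-fold lower number (0.98 log units; beyond the scatter) from compound 1 to compound 3 and an at least 17-fold lower number (1.23 log units; beyond the scatter) from compound 2 to compound 4; the limit leaves it open whether they differ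

The compounds shown leave open how the number would respond if an amine, a carboxylic acid or a nitrile stood in place of chloro or methyl, since only these two groups occupy that place. They also leave open whether a longer chain or a plain phenyl in place of propyl would give a readable number, and so how much of the step from propyl depends on the full 3,4,5-trimethoxyphenyl group.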